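Difluorophenyl ether in place of the carbamoyl ether

This account rests on a few compounds, and the source may have more. Where it says the series, first, only, none or still open, it means among the compounds named here.

Compound 2, `CC(C)[C@H](NC(=O)COc1cccc2ccccc12)C(=O)N[C@@H](CC(=O)O)C(=O)COc1ccc(C(N)=O)cc1`, carries a 4-carbamoylphenyl group on the ether oxygen beside the ketone. In a functional assay on Jurkat cells (Homo sapiens) (a lower number here means a stronger inhibitor, a higher number a weaker inhibitor), compound 2 gives only a limit of the assay, > 100000 nM. Compound 1, `CC(C)[C@H](NC(=O)COc1cccc2ccccc12)C(=O)N[C@@H](CC(=O)O)C(=O)COc1cc(C(F)(F)F)cc(C(F)(F)F)c1`, also reaches only a limit in this assay, > 100000 nM. Of the three values at hand, two sit at the limit of > 100000 nM in this assay, at which 2 of the 3 values shown sit, so compound 2 stands at the weak end of what this series shows. For the measured compounds named here, the one measured step out of compound 2 leads to compound 3, `CC(C)[C@H](NC(=O)COc1cccc2ccccc12)C(=O)N[C@@H](CC(=O)O)C(=O)COc1ccc(Oc2ccc(C(F)(F)F)cc2)cc1`, which in this assay gives 9300 nM; that step, an at least 10-fold lower number from compound 2 to compound 3 (1.03 log units; beyond the scatter), is the only change with a size on record here.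

Compound 4 is `CC(C)[C@H](NC(=O)COc1cccc2ccccc12)C(=O)N[C@@H](CC(=O)O)C(=O)COc1c(F)cccc1F`. The change from compound 2 is 2,6-difluorophenyl in place of 4-carbamoylphenyl on an oxygen on a saturated carbon. Going by the values given here, no measured pair shows this particular exchange, so the step from compound 2 to compound 3 is the only guide: it shows that a swap of the group on that ether oxygen can move the number well beyond the scatter, away from the limit. On that basis compound 4 is expected to come in below the limit by a step of about an at least 6.6-fold lower number from compound 2 to compound 4 (0.82 log units; beyond the scatter), with wide uncertainty in either direction. The estimate for compound 4 in this assay is 15000 nM, within a range from 1500 nM to 100000 nM.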

Compound 4, half-maximal inhibitory concentration: 2040 nM
Compound 4: middle estimate off by 7.4-fold (0.87 log units), on the high side; the range from low to high includes it.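

In this assay, 2,6-difluorophenyl in place of 4-carbamoylphenyl on the ether oxygen gives an at least 49-fold lower number from compound 2 to compound 4 (1.69 log units; beyond the scatter), so a number well clear of the limit at this position does not need the second aromatic ring that compound 3 carries. Compound 3 gives 9300 nM and compound 4 gives 2040 nM, and the lower number of the two belongs to the group with a single ring. Fluorine on the ring does not settle the outcome by itself: compound 1, with two trifluoromethyl groups on its phenyl ring, stays at a limit of the assay, > 100000 nM.

From the compounds shown here alone, the true size of the step remains unknown, since compound 2 gives only a limit and the step is therefore a bound: the limit of > 100000 nM in this assay, at which 2 of the 4 values shown sit. The compounds shown also leave open whether the fluorines of compound 4 contribute at all, or whether an unsubstituted phenyl, a single fluorine, a chlorine, a methoxy group or an amine on the same ring would give a similar number.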